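Amide nitrogen variation on the shared core: working notes

A few compounds are considered here, and "the series" means these few. Any claim that something is new, unique, unknown or untested is made for them only; others in the source may bear on it.

Measured so far:
Compound 1 `O=C(/C=C/c1coc2cc(O)ccc2c1=O)NCc1ccccc1` — in a functional assay on L02 cells (Homo sapiens) for inhibition, read by MTT assay, with a stated time of 48 h (on this read-out higher numbers stand for weaker inhibition and lower numbers for stronger inhibition), compound 1 gives > 200000 nM, a limit of the assay.
Compound 2 `Cc1ccccc1NC(=O)/C=C/c1coc2cc(O)ccc2c1=O` — in this assay compound 2 gives > 200000 nM, also a limit.
Compound 3 `Cc1ccc(CNC(=O)/C=C/c2coc3cc(O)ccc3c2=O)cc1` — in this assay compound 3 gives > 200000 nM, again a limit.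

Compound 3 thus stands at the limit, and so do the other two values shown (the limit of > 200000 nM in this assay, at which 3 of the 3 values shown sit). For the measured compounds named here, none of the measured steps is readable: a step that the two limits leave unreadable from compound 1 to compound 2, a step that the two limits leave unreadable from compound 1 to compound 3 and a step that the two limits leave unreadable from compound 2 to compound 3 all run between two limits, so their size cannot be told.

The next compound is compound 4 `O=C(/C=C/c1coc2cc(O)ccc2c1=O)Nc1ccccc1`. The change from compound 3 is phenyl in place of 4-methylbenzyl on an amide-type nitrogen. The measured steps that bear on this change are the three above, and every one of them is unreadable. No readable step is therefore expected in this assay from compound 3 to compound 4 either; the expected step is a number no higher from compound 3 to compound 4 (the limit leaves the size open). Compound 4 is expected to sit at the limit as well, with an estimate of 200000 nM in a range from 100000 nM to 400000 nM.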

Compound 4, half-maximal inhibitory concentration: > 200000 nM
Compound 4 was reported as a limit; the forecaster's own chance of this, stated with the estimate: 85%; the middle value sits exactly at the limit.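

The steps from compound 1, compound 2 and compound 3 to compound 4 all run between two limits in this assay, so none can be read: the limit of > 200000 nM in this assay, at which 4 of the 4 values shown sit. The compounds shown leave open whether any substituent on the amide nitrogen of the shared core gives a value inside the limit in this assay at all.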